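Replacing 4-methylpiperazin-1-yl with 5-fluoropyridin-2-yl on compound 1

A few compounds are considered here, and "the series" means these few. Any claim that something is new, unique, unknown or untested is made for them only; others in the source may bear on it.

Of the compounds shown here, three have been measured in a physicochemical assay for lipophilicity; a lower number here means a more polar compound, a higher number a more lipophilic compound. Compound 1 `CN1CCN(c2cc(C(F)(F)F)ccc2[C@H]2CCOc3cc(S(=O)(=O)Nc4nccs4)ccc32)CC1` gives 2.1, and compound 2 `Cn1nccc1-c1cc(C(F)(F)F)ccc1[C@H]1CCc2cc(S(=O)(=O)Nc3ncccn3)ccc21` gives 2.4, so these two lie within the scatter of each other. Compound 3 `Cc1ccc(-c2cc(C(F)(F)F)ccc2[C@H]2CCOc3cc(S(=O)(=O)Nc4ccncn4)ccc32)cn1` gives 3, which is higher than compound 1 by more than the scatter.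

Compound 4 `O=S(=O)(Nc1nccs1)c1ccc2c(c1)OCC[C@@H]2c1ccc(C(F)(F)F)cc1-c1ccc(F)cn1` departs from compound 1 in a single place: 5-fluoropyridin-2-yl in place of 4-methylpiperazin-1-yl on an aromatic carbon. Within the data shown here, no pair of measured compounds differs in only one place, so the evidence for this change is indirect. Compound 3 also carries a six-membered aromatic ring with 1 hetero atom in that place, though it differs elsewhere as well, and compound 3 gives 3. On that basis, a rise beyond the scatter is expected in this assay, and the expected change is a number 0.80 log units higher from compound 1 to compound 4 (beyond the scatter). For compound 4 the estimated value is 2.9, with an expected range from 2.4 to 3.4.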

Compound 4, distribution coefficient: 3.5
Compound 4: middle estimate off by 0.60 log units, on the low side, and the stated range ends below it.
By their numbers in this assay, from the lowest: compounds 1 and 2 (each within the scatter of the next); then compound 3; then compound 4.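

In this assay, the position on the aromatic carbon of the core of compound 1 now has a direct reading: 5-fluoropyridin-2-yl in place of 4-methylpiperazin-1-yl gives a number 1.40 log units higher from compound 1 to compound 4 (beyond the scatter), a large step. The earlier compounds shown here could speak to this place only indirectly, since they differ from compound 1 elsewhere too, whereas here a single exchange between two groups with the same number of heavy atoms moves the number this far. Nothing measured here accounts for the size of the step.

This one pair cannot separate the exchange of a non-aromatic ring for an aromatic one from the presence of the fluorine, and pyridin-2-yl without fluorine or morpholin-4-yl in this place would bear on that. From the compounds shown here alone, whether a step of this size holds on the cores of compound 2 and compound 3 also stays open.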